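A 4-methoxyphenyl step on a series held at a limit

The source may hold more compounds than are shown below. What is called first, only, known or untested is meant among the compounds shown, and "the series" means these compounds.

Compound 1 `COc1cc2ncnc(Nc3cc(O)[nH]n3)c2cc1OC`: < 100000 nM, a limit
Compound 2 `COc1cc2ncnc(Nc3cc(-c4ccccc4)[nH]n3)c2cc1OC`: < 100000 nM, a limit
Compound 3 `COc1cc2ncnc(Nc3cc(-c4ccc(Cl)cc4)[nH]n3)c2cc1OC`: < 100000 nM, a limit

In a functional assay on DU-145 cells (Homo sapiens) for cytotoxicity, read by MTT assay (a lower number here means a stronger inhibitor, a higher number a weaker inhibitor), compound 1 stands only at a limit, < 100000 nM, and has no exact number. All the measured compounds run into (the limit of < 100000 nM in this assay, at which 3 of the 3 values shown sit). Compound 4 `COc1ccc(-c2cc(Nc3ncnc4cc(OC)c(OC)cc34)n[nH]2)cc1` differs from compound 1 at one place: 4-methoxyphenyl in place of hydroxy on an aromatic carbon. The closest measured changes are a step that the two limits leave unreadable from compound 1 to compound 2 and a step that the two limits leave unreadable from compound 1 to compound 3, and neither has a readable size. They therefore suggest no direction, and the expected change, a step that the limit leaves unreadable from compound 1 to compound 4, is only a rough estimate. Compound 4 is estimated at 30000 nM, with an expected range of 5000 nM to 100000 nM. Another report as a limit alone is also expected to be likely.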

Compound 4, half-maximal inhibitory concentration: < 100000 nM
Compound 4: only a limit was reported; the forecaster's own chance of this, stated with the estimate: 65%; the middle value is on the limit's open side.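

Compound 4 is also reported only as a limit, like compound 1, compound 2 and compound 3, so no step among them can be read in this assay: the limit of < 100000 nM in this assay, at which 4 of the 4 values shown sit.

The compounds shown leave open how strongly each acts, and whether hydroxy, phenyl, 4-chlorophenyl or 4-methoxyphenyl makes any difference.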